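Aryl amide variation on a cyclopropane dicarboxamide series

The compounds below may be only part of what the source reports. "The series", "measured", "known", "first", "only" and "open" are said of these compounds alone.

Measured so far in a functional assay on A549 cells (Homo sapiens) for inhibition, read by CCK-8 assay, with a stated time of 72 h, tested at 10 uM; on this read-out lower numbers stand for less inhibition of growth and higher numbers for more inhibition of growth at the one concentration tested:
compound 1 `CN(C)C(=O)c1cc2cnc(Nc3ccc(NC(=O)C4(C(=O)Nc5ccc(O)cc5)CC4)cc3)nc2n1C1CCCC1` gives 94.4%
compound 2 `Cc1cccc(NC(=O)C2(C(=O)Nc3ccc(Nc4ncc5cc(C(=O)N(C)C)n(C6CCCC6)c5n4)cc3)CC2)c1` gives 86.1%
compound 3 `CN(C)C(=O)c1cc2cnc(Nc3ccc(NC(=O)C4(C(=O)Nc5cccc(F)c5)CC4)cc3)nc2n1C1CCCC1` gives 91.8%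

Compound 3 stands second highest of the three numbers in this assay. Its nearest neighbour is compound 1, the step of a number 2.6 percentage points lower from compound 1 to compound 3 (within the scatter) being within the scatter; the other measured step into compound 3, a number 5.7 percentage points higher from compound 2 to compound 3 (within the scatter), also lies within the scatter. The remaining measured pair, a number 8.3 percentage points lower from compound 1 to compound 2 (within the scatter), is within the scatter as well. Across the three aryl amide variants seen so far, no change in the terminal phenyl has moved this assay beyond its noise, so no ordering among compounds 1, 2 and 3 can be claimed.

Compound 4 `CN(C)C(=O)c1cc2cnc(Nc3ccc(NC(=O)C4(C(=O)Nc5ccc(Cl)cc5)CC4)cc3)nc2n1C1CCCC1` differs from compound 3 in one place: 4-chlorophenyl in place of 3-fluorophenyl on an amide-type nitrogen. Among the compounds with values here, the steps that bear on this change are the two into compound 3, from a hydroxy- and from a methyl-substituted phenyl, and the step between those two; all three were within the scatter. A further aryl variation at the same amide-type nitrogen is therefore expected to give no step beyond the scatter in this assay, with compound 4 expected to sit close to compound 3, the expected step being a number 0.8 percentage points lower from compound 3 to compound 4 (within the scatter). The estimate for compound 4 is 91%, with a range from 80% to 98%.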

Compound 4, percent growth inhibition at one concentration: 101%
The estimate for compound 4 lay 10 percentage points below the measured number, and the stated range ends below it.
By their numbers in this assay, from the lowest: compounds 2, 3, 1 and 4 (each within the scatter of the next, the first and the last beyond it).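

Within the data shown here, at the amide-type nitrogen, the aryl group can now move this assay beyond its scatter: 4-chlorophenyl in place of 3-methylphenyl gives a number 14.9 percentage points higher from compound 2 to compound 4 (beyond the scatter) and is the first such step. The other two new steps stay within the scatter, with a number 9.2 percentage points higher from compound 3 to compound 4 (within the scatter) for 4-chlorophenyl in place of 3-fluorophenyl and a number 6.6 percentage points higher from compound 1 to compound 4 (within the scatter) for chloro in place of hydroxy, so compound 4 is separated only from compound 2 and cannot be ranked against compound 1 or compound 3. No measurement is at hand that explains this result.

Still open, from the compounds shown here alone, is whether the step into compound 4 follows from the chloro group or from where it stands on the phenyl ring, a question that 3-chlorophenyl and 4-methylphenyl at the same nitrogen would address. Also open, going by these compounds, is how this assay responds to a 4-aminophenyl or 4-carboxyphenyl group, or to a benzyl group, at this nitrogen.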